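Adding bromo to the core of compound 2

This account rests on a few compounds, and the source may have more. Where it says the series, first, only, none or still open, it means among the compounds named here.

Values in a functional assay on HL-60 cells (Homo sapiens) for antiproliferative activity, read by CellTiter-Glo, with a stated time of 72 h (a lower number here means a stronger inhibitor, a higher number a weaker inhibitor), are these:
- Compound 1 `CO[C@@H]1[C@H](N(C)c2ncc(-c3c[nH]c4ccc(F)cc34)s2)C[C@H]2O[C@]1(C)n1c3ccccc3c3c4c(c5c6ccccc6n2c5c31)C(=O)NC4` gives > 10000 nM as a limit
- Compound 2 `CO[C@@H]1[C@H](N(C)c2ncc(-c3c[nH]c4ccc(Cl)cc34)s2)C[C@H]2O[C@]1(C)n1c3ccccc3c3c4c(c5c6ccccc6n2c5c31)C(=O)NC4` gives > 10000 nM as a limit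
- Compound 3 `CO[C@@H]1[C@H](N(C)c2ncc(-c3c[nH]c4ccc(Br)cc34)s2)C[C@H]2O[C@]1(C)n1c3ccccc3c3c4c(c5c6ccccc6n2c5c31)C(=O)NC4` gives > 10000 nM as a limit

Compound 2 gives > 10000 nM as a limit and not as a number. For the measured compounds named here, the whole set stands the same way, with the limit of > 10000 nM in this assay, at which 3 of the 3 values shown sit, as the only evidence. Compound 4 `CO[C@@H]1[C@H](N(C)c2ncc(-c3c[nH]c4ccc(Cl)cc34)s2)C[C@H]2O[C@]1(C)n1c3ccccc3c3c4c(c5c6cc(Br)ccc6n2c5c31)C(=O)NC4` is compound 2 with bromo in place of hydrogen on an aromatic carbon, and the change in detail is bromo in place of hydrogen on an aromatic carbon with nothing else altered.

The measured steps are a step that the two limits leave unreadable from compound 1 to compound 2 and a step that the two limits leave unreadable from compound 1 to compound 3 and a step that the two limits leave unreadable from compound 2 to compound 3 and each swaps one halogen for another. Their sizes cannot be read, and none of them puts bromo where hydrogen stood. They therefore set no size or direction, so no step beyond the scatter is expected in this assay and another limit is the likeliest report. This expectation rests on compound 2 with > 10000 nM as its limit. Compound 4 is estimated at 10000 nM with an expected range from 3000 nM to 30000 nM in this assay. The estimate means an expected a number no higher from compound 2 to compound 4 (the limit leaves the size open) and no more.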

Compound 4, half-maximal inhibitory concentration: > 10000 nM
Compound 4 gave a limit, no number; the forecaster's own chance of this, stated with the estimate: 80%; the middle value sits exactly at the limit.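

Compound 4 gives > 10000 nM in this assay, a limit and not a number. Compound 2 also stands only as a limit, and the step between compound 2 and compound 4 cannot be read. The compounds shown leave open what size of number, if any, either halogen change would give in this assay.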